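Replacing Dimethylamino with Benzoxazolyl: Expected Cytotoxicity

The compounds below may be only part of what the source reports. "The series", "measured", "known", "first", "only" and "open" are said of these compounds alone.

Of the compounds shown here, three sharing one core have been tested in a toxicity assay on NIH3T3 cells (Mus musculus) for cytotoxicity, read by resazurin assay; on this read-out lower numbers stand for an effect already at smaller amounts and higher numbers for an effect only at larger amounts of compound. Compound 1, `CN(C)c1ccc(NCc2cncn2Cc2ccc(-c3ccccc3)cc2)cc1-c1ccccc1`, gives > 1000 nM in this assay, which is a limit of the assay rather than a measured number. Compound 2, `COC(=O)c1ccc(NCc2cncn2Cc2cccc(F)c2)cc1-c1ccccc1`, likewise gives > 1000 nM, again a limit. Compound 3, `Cc1cccc(-c2cccc(NCc3cncn3Cc3ccccc3)c2)c1`, gives > 1000 nM, also a limit. So every value seen so far sits at the limit of > 1000 nM in this assay, at which 3 of the 3 values shown sit, and compound 1 stands exactly where the other two stand, with no number that separates it from them.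

Compound 4, `c1ccc(-c2ccc(Cn3cncc3CNc3ccc(-c4nc5ccccc5o4)c(-c4ccccc4)c3)cc2)cc1`, has not yet been measured. It differs from compound 1 in one place: 1,3-benzoxazol-2-yl in place of dimethylamino on an aromatic carbon. With no measured step between any pair of these compounds, there is no basis for expecting a large change in either direction. The step that the limit leaves unreadable from compound 1 to compound 4 is expected to be small, within the scatter, with the result most likely again at the limit. Compound 4 is therefore estimated at 1500 nM, in a range from 500 nM to 5000 nM.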

Compound 4, half-maximal effective concentration: > 10000 nM
Compound 4: only a limit was reported; the forecaster's own chance of this, stated with the estimate: 60%; middle value at least 6.6-fold (0.82 log units) away from the limit.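

Among these compounds, compound 1 and compound 4 each give only a limit and not a number, so no step from one to the other can be read. The compounds shown leave open at what concentration any of them would show an effect in this assay.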